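Trifluoromethyl in place of an ester on a urea

This account rests on a few compounds, and the source may have more. Where it says the series, first, only, none or still open, it means among the compounds named here.

Measured so far in an ADME assay on HepG2 cells (Homo sapiens) for cytotoxicity, with a stated time of 72 h; on this read-out higher numbers stand for an effect only at larger amounts of compound and lower numbers for an effect already at smaller amounts:
- compound 1 `COC(=O)c1ccc(NC(=O)Nc2cc(C)nc3ccccc23)cc1`: compound 1 gives 20000 nM.
- compound 2 `COc1ccccc1NC(=O)Nc1cc(C)nc2ccccc12`: for compound 2 the result is a limit of the assay, > 25000 nM.

Within the data shown here, compound 1 is thus the only member of this pair with a number in this assay; the other value is a limit, since (the limit of > 25000 nM in this assay, at which 1 of the 2 values shown sits). Among the measured compounds shown here, the two compounds share the same core and differ in the group carried on the outer ring of the urea, but no step between them is given, so their two results can only be stated side by side.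

Compound 3 `Cc1cc(NC(=O)Nc2ccc(C(F)(F)F)cc2)c2ccccc2n1` is not yet measured. It differs from compound 1 in one place: trifluoromethyl in place of methoxycarbonyl on an aromatic carbon. For the measured compounds named here, no measured step of this kind is available for comparison, so the expectation rests on compound 1 alone, whose result is 20000 nM. The expected step from compound 1 to compound 3 is no change at the digits printed from compound 1 to compound 3 (within the scatter), which means no change beyond the usual scatter in either direction. Compound 3 is therefore estimated to give 20000 nM in this assay, with a range from 8000 nM to 50000 nM, and a fair chance that only a limit is reported.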

Compound 3, half-maximal effective concentration: 23000 nM
Estimate against measurement, compound 3: 1.2-fold (0.06 log units) below, within the range that was stated.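

In this assay, among these compounds, the first step that can be read is a 1.2-fold higher number from compound 1 to compound 3 (0.06 log units; within the scatter), so this exchange at an aromatic carbon para to a large group shows no change beyond the usual scatter. The two groups have the same number of heavy atoms but differ in kind: methoxycarbonyl brings two oxygens, a double bond outside aromatic rings and two hydrogen-bond acceptors, while trifluoromethyl brings three fluorines and no hydrogen-bond acceptors. Among the compounds shown here, in this one pair, then, removing those oxygens and that double bond from this position leaves the cytotoxicity read-out within the scatter, a comparison that the two earlier compounds, with no step between them, could not offer.

On these data alone, whether a group of a different kind at the same place, such as an amine or a carboxylic acid, would move the read-out beyond the scatter remains open, since one exchange says nothing about the others. Compound 2 still gives a limit and not a number, and no step links it to the other compounds, so its outer-ring group cannot be compared with theirs: the limit of > 25000 nM in this assay, at which 1 of the 3 values shown sits.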